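The compounds below may be only part of what the source reports. "The series", "measured", "known", "first", "only" and "open" are said of these compounds alone.

Compound 1, whose structure is `Cc1ccc(-c2cc(Br)ccc2OCc2ccc(F)cc2F)n1-c1cc(C(=O)O)cc(N2CCCC2=O)c1`, has no single number in an ADME assay on the whole organism (plasma) for pharmacokinetics, with Rattus norvegicus as the target, at a dose of 3 mg/kg by the oral route (on this read-out higher numbers stand for higher exposure at the dose given and lower numbers for lower exposure), where the outcome for it is given as "not determined" (no result reported). The one companion measured there is compound 2, with the structure `Cc1ccc(-c2cc(Cl)ccc2OCc2ccccc2)n1-c1cc(Br)cc(C(=O)O)c1`, and in this assay compound 2 gives 100000000 ng.h/mL. For the measured compounds named here, compound 2 differs from compound 1 in more than one place, so no single step between the two can be drawn from its value.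

The compound now in question is compound 3, with the structure `CC(=O)Nc1cc(C(=O)O)cc(-n2c(C)ccc2-c2cc(Br)ccc2OCc2ccc(F)cc2F)c1`. It differs from compound 1 by one change: acetamido in place of 2-oxopyrrolidin-1-yl on an aromatic carbon.

Going by the values given here, no measured pair shows the effect of such a change here. Compound 1 itself carries no number, so there is no anchor from which a step could be counted. The expectation for compound 3 is therefore stated with a wide range: in this assay compound 3 is expected to give about 5000 ng.h/mL, between 300 ng.h/mL and 80000 ng.h/mL.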

Compound 3, area under the concentration-time curve: 350000000 ng.h/mL
Beside the measured number, compound 3's estimate is 70000-fold (4.85 log units) below it; the measured number lies above the stated range.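

For the compounds shown here, compound 1 carries no single number, so no step from it to compound 3 can be read from this result. The compounds shown leave open how acetamido in place of 2-oxopyrrolidin-1-yl changes exposure in the rat. No evidence bearing on this result is at hand.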